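A Methoxyphenyl Swap on Compound 3

This account rests on a few compounds, and the source may have more. Where it says the series, first, only, none or still open, it means among the compounds named here.

In a functional assay on HepG2 cells (Homo sapiens) for inhibition, read by MTT assay, with a stated time of 48 h (on this read-out higher numbers stand for weaker inhibition of growth and lower numbers for stronger inhibition of growth), compound 1 (`COc1cc(C2=NN(C(=O)c3ccc(C)nc3)C(c3cn(C)c4ccccc34)C2)cc(OC)c1OC`) gives 310 nM and compound 2 (`Cn1cc(C2CC(c3ccc(Cl)cc3)=NN2C(=O)c2cccnc2)c2cc(Br)ccc21`) gives 5800 nM on the same scale. Compound 3 (`COc1ccc2c(c1)c(C1CC(c3ccc(F)cc3)=NN1C(=O)c1ccc(OC)nc1)cn2C`) reads 220 nM here, which is level with compound 1 within the scatter and far lower than compound 2. Compound 4 (`COc1cccc(C2=NN(C(=O)c3ccc(OC)nc3)C(c3cn(C)c4ccc(OC)cc34)C2)c1`) has 3-methoxyphenyl in place of 4-fluorophenyl on a carbon with a double bond to nitrogen. For the measured compounds named here, no measured pair differs in only one place, so nothing yet shows directly what this swap does. An estimated step of a 1.6-fold higher number from compound 3 to compound 4 (0.20 log units; within the scatter) towards a slightly higher number in this assay would stay within the usual scatter. Compound 4 is expected at 350 nM with an estimated range from 100 nM to 1500 nM around that middle.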

Compound 4, concentration for 50% growth inhibition: 190 nM
Beside the measured number, compound 4's estimate is 1.8-fold (0.27 log units) above it; low and high end bracket the measured number.
By their numbers in this assay, from the lowest: compounds 4, 3 and 1 (each within the scatter of the next); then compound 2.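

For the compounds shown here, compound 3 and compound 4 form the first pair that differs in only one place, and putting 3-methoxyphenyl in place of 4-fluorophenyl in this assay gives a step within the scatter (a 1.2-fold lower number from compound 3 to compound 4 (0.06 log units; within the scatter)). On the carbon with a double bond to nitrogen, the two groups therefore read level, even though the entering group adds a hydrogen-bond acceptor. No separate measurement bears on why they read alike.

Going by these compounds, whether a phenyl carrying an amine or a carboxylic acid would also read level with compound 3 stays open. So does whether this swap behaves the same way on other versions of the shared core.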